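Swapping one small ring for another on an adenosine binder

A few compounds are considered here, and "the series" means these few. Any claim that something is new, unique, unknown or untested is made for them only; others in the source may bear on it.

Of the compounds shown here, two have so far been tested in an assay on membranes from HeLa cells for displacement of a labelled ligand from adenosine receptor A3 (Homo sapiens), read by scintillation counting, with a stated time of 180 min, tested at 1 uM; a lower number here means less inhibition, a higher number more inhibition at the concentration tested (going by the name of the read-out). Compound 1, drawn as `COC(=O)C1=C(C)NC(=O)NC1c1cccs1`, gives 3% in this assay. Compound 2, drawn as `CC1=C(c2ncc(C)o2)C(c2ccoc2)NC(=O)N1`, gives 1% in this assay. These two numbers lie within the usual scatter of each other, so neither compound can be said to displace the labelled ligand more than the other; both values sit low in this assay.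

Compound 3, drawn as `CC1=C(c2ncc(C)o2)C(c2cccs2)NC(=O)N1`, has not yet been measured. It differs from compound 2 in a single place: thiophen-2-yl in place of furan-3-yl on a saturated ring carbon. Compound 1 already carries a thiophen-2-yl group at that same place on the shared core, though its other substituents differ, and its number in this assay stays near zero.

Among the compounds with values here, no measured pair shows what this exchange alone does to the read-out. Given that both measured compounds show almost no inhibition, the step of a number 2 percentage points higher from compound 2 to compound 3 (within the scatter) is expected to be no larger than the scatter, in either direction. Compound 3 is therefore estimated to give 3% in this assay, with a likely range from -6% to 12%.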

Compound 3, a percentage reported as inhibition, at one concentration (the size of the read-out at that concentration, not a potency): 1%
For compound 3 the middle estimate is 2 percentage points above the measured one, within the range that was stated.
By their numbers in this assay, from the lowest: compounds 2, 3 and 1 (each within the scatter of the next).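

In this assay, within the data shown here, thiophen-2-yl in place of furan-3-yl on the saturated ring carbon gives no change at the digits printed from compound 2 to compound 3 (within the scatter), so this is the first direct comparison at that position, and the two rings cannot be told apart by this read-out. The other new pair concerns a different place: with thiophen-2-yl present in both compounds, 5-methyl-1,3-oxazol-2-yl in place of methoxycarbonyl on the double-bonded ring carbon gives a number 2 percentage points lower from compound 1 to compound 3 (within the scatter), so these two groups cannot be told apart here either. No supporting information bears on these results, and with every value lying close to zero, neither pair can show how much either position matters for displacing the labelled ligand.

Still open, as far as these compounds go, is whether any group at these two positions can give a read-out clearly beyond the scatter of these three compounds. A phenyl ring on the saturated ring carbon, or a carboxylic acid or a longer ester chain on the double-bonded ring carbon, would test this, since all the exchanges shown so far stay within the scatter.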